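Trimming a Ring-Bearing Side Chain on a Chlorinated Core

The source may hold more compounds than are shown below. What is called first, only, known or untested is meant among the compounds shown, and "the series" means these compounds.

Measured compounds:
Compound 1 `COC(c1cc(Cl)c2c(c1Cl)C(=O)N(Cc1c(C)cc(C)[nH]c1=O)CC2)C1CCOC1` gives 130 nM; 30 nM; 1.9 nM; 0.6 nM (4 entries)
Compound 2 `Cc1cc(C)c(CN2CCc3c(Cl)cc([C@H](CO)[C@H]4CCCO4)c(Cl)c3C2=O)c(=O)[nH]1` gives 8 nM

In an assay for inhibition of histone-lysine N-methyltransferase EZH2 variant Y641N (Homo sapiens), read by scintillation counting, with a stated time of 60 min, in the presence of a further agent that is not named here (on this read-out lower numbers stand for stronger inhibition and higher numbers for weaker inhibition), compound 1 shows a wide spread across its repeats (the several entries of compound 1 in this assay, 130 nM; 30 nM; 1.9 nM; 0.6 nM (4 entries)). Going by the values given here, compound 2 gives 8 nM in this assay, the only number for it, with one further entry that carries no single number. Compound 3 `Cc1cc(C)c(CN2CCc3c(Cl)cc([C@H](C)CO)c(Cl)c3C2=O)c(=O)[nH]1` differs from compound 2 by a group of 4 heavy atoms (3 carbon, 1 oxygen; no ring) in place of a group of 8 heavy atoms (6 carbon, 2 oxygen; one five-membered non-aromatic ring with 1 hetero atom), on an aromatic carbon: in words, a group of 4 heavy atoms (3 carbon, 1 oxygen; no ring) in place of a group of 8 heavy atoms (6 carbon, 2 oxygen; one five-membered non-aromatic ring with 1 hetero atom), on an aromatic carbon. Among the compounds with values here, no measured step of this kind exists here, so a modest weakening is expected, a 3.8-fold higher number from compound 2 to compound 3 (0.57 log units; beyond the scatter). Compound 3 is estimated at 30 nM, within 5 nM to 200 nM.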

Compound 3, inhibition constant: 17 nM
Compound 3: middle estimate off by 1.8-fold (0.25 log units), on the high side; low and high end bracket the measured number.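

This gives the position on the aromatic carbon its first measured step: in this assay there is a 2.1-fold higher number from compound 2 to compound 3 (0.33 log units; beyond the scatter). The five-membered ring can therefore leave the side chain at only a modest cost, with the smaller 1-(hydroxymethyl)ethyl group still giving a measurable inhibition constant. Compound 1 could not show this, since its entries spread too widely to serve as a reference: the several entries of compound 1 in this assay, 130 nM; 30 nM; 1.9 nM; 0.6 nM (4 entries)

Still open, on these data alone, is how much the hydroxyl group of this chain contributes. It is also unknown what an amine or a carboxylic acid at this position would give.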